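Chlorine for Fluorine on the Benzyl Group of Compound 4

A few compounds are considered here, and "the series" means these few. Any claim that something is new, unique, unknown or untested is made for them only; others in the source may bear on it.

Compound 1 `COc1ccc(N2C(=O)N(Cc3c(F)cc(F)cc3F)c3ccccc3S2(=O)=O)cc1OC` gives 2 nM in an assay on HEK293 cells for displacement of a labelled ligand from Orexin receptor type 2 (Homo sapiens), read by scintillation counting, with a stated time of 90 min; a higher number here means a weaker inhibitor, a lower number a stronger inhibitor. Among the three compounds measured it sits second highest; compound 2 `COc1cc(N2C(=O)N(Cc3c(F)cc(F)cc3Cl)c3ccccc3S2(=O)=O)cnc1OC` gives 1.59 nM, within the scatter of compound 1, while compound 3 `COc1cc(N2C(=O)N(Cc3c(F)cc(F)cc3F)c3ccccc3S2(=O)=O)ccn1` gives 63.1 nM, and the step of a 32-fold higher number from compound 1 to compound 3 (1.50 log units; beyond the scatter) is large and beyond the scatter. That step, however, concerns the group on the amide-type nitrogen in the ring, not the benzyl group.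

Compound 4 `COc1ccc(N2C(=O)N(Cc3c(F)cccc3Cl)c3ccccc3S2(=O)=O)cc1OC` differs from compound 1 at the benzyl group: 2-chloro-6-fluorophenyl in place of 2,4,6-trifluorophenyl on a saturated chain carbon bound to an amide-type nitrogen in a ring

Within the data shown here, no measured step isolates this change. Compound 2 carries a 2-chloro-4,6-difluorobenzyl group together with a different ring on the amide-type nitrogen, and its value lies within the scatter of compound 1, which gives no sign that a chlorine-bearing benzyl group shifts the number on its own. The step of a 1.3-fold higher number from compound 1 to compound 4 (0.10 log units; within the scatter) is therefore expected to stay within the scatter. Compound 4 is estimated at 2.5 nM, with a range of 1 nM to 7 nM.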

Compound 4, inhibition constant: 0.794 nM
Estimate against measurement, compound 4: 3.1-fold (0.50 log units) above, outside the stated range (below it).
By their numbers in this assay, from the lowest: compounds 4, 2 and 1 (each within the scatter of the next, the first and the last beyond it); then compound 3.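

In this assay, the benzyl group proves to be a place where the number responds: with the 3,4-dimethoxyphenyl group held fixed, 2,4,6-trifluorobenzyl to 2-chloro-6-fluorobenzyl gives a 2.5-fold lower number from compound 1 to compound 4 (0.40 log units; beyond the scatter), a modest step toward a stronger inhibitor. Among these compounds, the only earlier step concerned the group on the amide-type nitrogen, so this is the first measured single change on the benzyl side, and the change is tolerated here rather than harmful. Nothing available explains why the number moves with this change.

The change brings in chlorine and removes fluorine at once, so the compounds shown do not separate the share of each. As far as these compounds go, how a benzyl group carrying a methyl or a nitrile in place of the chlorine would read, or an unsubstituted benzyl group, also remains open.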